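The source may report more compounds than this note shows. Statements on the series, on what has been measured and on what is new or still open speak of the compounds shown alone.

Compound 1 `COc1ccc(-c2nc(SCC(=O)c3sc(-c4ccccc4)nc3C)[nH]c(=O)c2C#N)cc1` was tested in a functional assay on U-87MG ATCC cells for antiproliferative activity against U-87 MG (Homo sapiens), read by MTT assay, with a stated time of 48 h, tested at 5 uM (a lower number here means a stronger effect, a higher number a weaker effect of the compound at the concentration tested), and gives 97.3%. Among the three compounds measured it stands second highest. Compound 2 `COc1ccc(-c2nc(C)c(C(=O)CSc3nc(-c4ccc(OC)cc4)c(C#N)c(=O)[nH]3)s2)cc1` gives 97%; the step of a number 0.3 percentage points lower from compound 1 to compound 2 (within the scatter) lies within the scatter. Compound 3 `Cc1nc(-c2ccc(Cl)cc2)sc1C(=O)CSc1nc(-c2ccc(Cl)c(Cl)c2)c(C#N)c(=O)[nH]1` gives 101%, which is also within the scatter of compound 1. Compound 4 `Cc1nc(-c2ccccc2)sc1C(=O)CSc1nc(-c2cccc(Cl)c2)c(C#N)c(=O)[nH]1` has not yet been measured. It differs from compound 1 in one place: 3-chlorophenyl in place of 4-methoxyphenyl on an aromatic carbon. For the measured compounds named here, only one measured step bears on this change, the one in which methoxy takes the place of hydrogen on an aromatic carbon, a number 0.3 percentage points lower from compound 1 to compound 2 (within the scatter); it was within the scatter, and no measured step covers a chlorine entering. No step beyond the scatter is therefore expected. Compound 4 is expected to give 98%, in the range 90% to 106%, a step of a number 0.7 percentage points higher from compound 1 to compound 4 (within the scatter).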

Compound 4, a percentage reported as activity, at one concentration (the size of the read-out at that concentration, not a potency): 86.9%
The estimate for compound 4 lay 11.1 percentage points above the measured number; the measured number lies below the stated range.
By their numbers in this assay, from the lowest: compound 4; then compounds 2, 1 and 3 (each within the scatter of the next).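

In this assay, 3-chlorophenyl in place of 4-methoxyphenyl on the aromatic carbon ortho to a cyano group gives a number 10.4 percentage points lower from compound 1 to compound 4 (beyond the scatter). This is the first step shown that clears the usual scatter, so the group on this carbon can change the effect, though only modestly. Nothing measured here explains the step. The swap changes both the substituent and where it sits on the phenyl ring, so the compounds shown cannot separate the two. A 3-methoxyphenyl or 3-aminophenyl group on this carbon would help tell them apart.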